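A few compounds are considered here, and "the series" means these few. Any claim that something is new, unique, unknown or untested is made for them only; others in the source may bear on it.

Working notes on the series. All four compounds share one core and differ only in the aryl group on the nitrogen on an aromatic ring. Compound 1 `Cc1n[nH]c2ccc(-c3nc4cnc(N5CCN(C)CC5)cn4c3Nc3ccccc3F)cc12` has in a functional assay on CWR22R cells (Homo sapiens) for inhibition, with a stated time of 120 h (on this read-out higher numbers stand for weaker inhibition and lower numbers for stronger inhibition), the entry "not determined" (no result reported), and compound 3 `Cc1n[nH]c2ccc(-c3nc4cnc(N5CCN(C)CC5)cn4c3Nc3cccc(Cl)c3)cc12` has in this assay the entry "not determined" (no result reported); no number was reported for either. In this assay compound 2 `Cc1n[nH]c2ccc(-c3nc4cnc(N5CCN(C)CC5)cn4c3Nc3ccc(F)cc3)cc12` gives 33600 nM, a weak inhibition. Compound 3 therefore stands without a number, and with compound 1 also lacking one, nothing on the numbers places compound 3 against compound 2.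

Compound 4 `Cc1n[nH]c2ccc(-c3nc4cnc(N5CCN(C)CC5)cn4c3Nc3ccc(Cl)cc3F)cc12` is compound 3 with 4-chloro-2-fluorophenyl in place of 3-chlorophenyl on a nitrogen on an aromatic ring. Among the measured compounds shown here, no step between measured compounds exists in this set, so neither the size nor the direction of this step can be read from the series; the only number in hand belongs to compound 2, which in this assay gives 33600 nM, and compound 4, like compound 2, carries a halogenated phenyl on the same nitrogen. On that basis compound 4 is expected to sit in the same weak range, with the possibility that only a limit is reported. Compound 4 is estimated at 20000 nM in this assay, with a range from 4000 nM to 80000 nM.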

Compound 4, half-maximal inhibitory concentration: 14100 nM
Estimate against measurement, compound 4: 1.4-fold (0.15 log units) above; low and high end bracket the measured number.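

The series now has its first readable step at this nitrogen: in this assay, a 2.4-fold lower number from compound 2 to compound 4 (0.38 log units; beyond the scatter), with 4-chloro-2-fluorophenyl in place of 4-fluorophenyl. The aryl group on this nitrogen can therefore shift the read-out beyond the usual scatter, though the step is modest and compound 4 at 14100 nM still shows weak inhibition. Steps to compound 1 and compound 3 cannot be read, and nothing on hand explains the shift.

Which part of the change carries the step stays open, since 4-chloro-2-fluorophenyl and 4-fluorophenyl also differ in how the halogens are arranged on the ring. Also open, from the compounds shown here alone, is how this read-out responds to a phenyl carrying no halogen at all, such as one bearing a methoxy group or a carboxylic acid.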